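The compounds below may be only part of what the source reports. "The series", "measured", "known", "first", "only" and "open" are said of these compounds alone.

Compound 1 `CC(C)CC1OCCC(Cl)=C1[Si](C)(C)C`: 27000 nM
Compound 2 `CCC(C)[C@H]1O[C@@H](C)CC(Cl)=C1[Si](C)(C)C`: > 100000 nM

Both compounds were tested in a functional assay on A2780 cells (Homo sapiens) for antiproliferative activity; on this read-out lower numbers stand for stronger inhibition of growth and higher numbers for weaker inhibition of growth. Compound 1 gives 27000 nM in this assay, a measured number. Compound 2 reaches only the limit of this assay, reported as > 100000 nM, so for compound 2 no exact number is known. Where compound 2 stands is thus described by the limit of > 100000 nM in this assay, at which 1 of the 2 values shown sits. Among the measured compounds shown here, no step between two measured compounds that differ in a single place is available here, so the two values show only that compound 1 was resolved to a number while compound 2 was not.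

Compound 3 `C[C@H]1CC(Cl)=C([Si](C)(C)C)[C@@H](C2CCCCC2)O1` has not yet been measured in this assay. It differs from compound 2 in one place: cyclohexyl in place of sec-butyl on a saturated ring carbon. For the measured compounds named here, with only a limit for compound 2 and no measured step to lean on, the size and direction of the change are uncertain; a move back toward a measurable number is possible but not assured. Compound 3 is expected to give about 60000 nM in this assay, with a range from 15000 nM to 200000 nM. This means the expected step of an at least 1.6-fold lower number from compound 2 to compound 3 (0.22 log units; that floor lies within the scatter).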

Compound 3, concentration for 50% growth inhibition: 17000 nM
Estimate against measurement, compound 3: 3.5-fold (0.55 log units) above; measured number inside the range.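

In this assay, among the compounds shown here, cyclohexyl in place of sec-butyl on a saturated ring carbon, next to the ring oxygen, gives an at least 5.8-fold lower number from compound 2 to compound 3 (0.76 log units; beyond the scatter), the first readable step between two compounds that differ in one place. This shows that the position is not indifferent to the group it carries: with the rest of the molecule unchanged, the swap from an open chain to a ring of carbon only brings the read-out to a measured number, with compound 3 at 17000 nM. The step is a floor and its true size remains unknown, because compound 2 has a limit of the assay and not a number: the limit of > 100000 nM in this assay, at which 1 of the 3 values shown sits.

This single change cannot separate the effect of having a ring from that of having more carbon atoms, as cyclohexyl differs from sec-butyl in both. From the compounds shown here alone, how a phenyl ring, a longer chain or a group bearing an amine would fare at this position stays open, as does whether the same swap would give a similar step on the core of compound 1.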